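The source may hold more compounds than are shown below. What is called first, only, known or untested is meant among the compounds shown, and "the series" means these compounds.

The measured compounds:

Compound 1, `O=C(CCc1cccc(C(F)(F)F)c1)Nc1cc(Oc2ccc3nc(NC(=O)C4CC4)sc3c2)ccc1F`: in an ADME assay on HT-29 cells (Homo sapiens) for cytotoxicity, read by luminescence and CellTiter-Glo, with a stated time of 12 h (on this read-out lower numbers stand for higher toxicity in this test and higher numbers for lower toxicity in this test), compound 1 gives > 50000 nM, a limit of the assay rather than a number.
Compound 2, `CCOC(=O)c1cccc(NC(=O)Nc2cc(Oc3ccc4nc(NC(=O)C5CC5)sc4c3)ccc2F)c1`: in this assay compound 2 gives > 50000 nM, again a limit of the assay.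
Compound 3, `O=C(Nc1nc2ccc(Oc3ccc(F)c(NCc4cccc(C(F)(F)F)c4)c3)cc2s1)C1CC1`: in this assay compound 3 gives "not determined" (no result reported), so no result is available for it.

Compound 1 therefore stands only at a limit in this assay, and nothing places it more precisely: one further value is also a limit, and the third entry carries no number at all. Going by the values given here, the one measured step that differs in a single place, the step from compound 1 to compound 2, is a step that the two limits leave unreadable from compound 1 to compound 2, the change being (3-(ethoxycarbonyl)phenyl)amino in place of 2-(3-(trifluoromethyl)phenyl)ethyl on a carbonyl carbon.

Compound 4, `CC(=O)c1cccc(NC(=O)Nc2cc(Oc3ccc4nc(NC(=O)C5CC5)sc4c3)ccc2F)c1`, departs from compound 1 by (3-acetylphenyl)amino in place of 2-(3-(trifluoromethyl)phenyl)ethyl on a carbonyl carbon. Among the compounds with values here, the step from compound 1 to compound 2 is the only measured step that bears on this change, and its size cannot be read, since (the limit of > 50000 nM in this assay, at which 2 of the 3 values shown sit).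

Compound 4 is thus expected to sit at the same limit, with the step from compound 1 to compound 4 estimated at a number no higher from compound 1 to compound 4 (the limit leaves the size open). Compound 4 is expected at 50000 nM, in a range from 20000 nM to 100000 nM.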

Compound 4, half-maximal cytotoxic concentration: > 50000 nM
Compound 4: no number, only a limit; the forecaster's own chance of this, stated with the estimate: 85%; the middle value sits exactly at the limit.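

In this assay no new step can be read among compound 1, compound 2 and compound 4, which all stand at a limit of the assay and not at a number (their shared reading is this: the limit of > 50000 nM in this assay, at which 3 of the 4 values shown sit). The compounds shown leave open how far each lies past that limit, and whether the changes among them make any difference.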